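A few compounds are considered here, and "the series" means these few. Any claim that something is new, unique, unknown or untested is made for them only; others in the source may bear on it.

Compound 1, `Cc1ccccc1N/N=C1\CCC(C)n2c1ncc(C(=O)O)c2=O`: in a functional assay on the whole organism for inhibition, with Rattus norvegicus as the target (a higher number here means that more compound is needed for the effect, a lower number that less compound is needed), compound 1 gives only a limit, > 100 umol/kg (the limit of > 100 umol/kg in this assay, at which 1 of the 3 values shown sits).
Compound 2, `Cc1cccc(N/N=C2\CCC(C)n3c2ncc(C(=O)O)c3=O)c1`: in this assay compound 2 gives 72.5 umol/kg.
Compound 3, `CC1CC/C(=N\Nc2ccccc2C(F)(F)F)c2ncc(C(=O)O)c(=O)n21`: in this assay compound 3 gives only a limit, > 1000 umol/kg (the limit of > 1000 umol/kg in this assay, at which 1 of the 3 values shown sits).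

Compound 2 differs from compound 1 by 3-methylphenyl in place of 2-methylphenyl on an amine nitrogen, and the step in this assay is an at least 1.3-fold lower number from compound 1 to compound 2 (0.13 log units; that floor lies within the scatter). Compound 3 differs from compound 1 by trifluoromethyl in place of methyl on an aromatic carbon; the step is a step that the two limits leave unreadable from compound 1 to compound 3. Compound 4, `CC1CC/C(=N\Nc2cccc(C(F)(F)F)c2)c2ncc(C(=O)O)c(=O)n21`, has not been measured; it differs from compound 2 by trifluoromethyl in place of methyl on an aromatic carbon. This is the same kind of change as that from compound 1 to compound 3, but the surroundings differ: there the group stands ortho to a large group, here meta to a large group. The earlier step gives no readable size, so the expectation for compound 4 rests on compound 2 with 72.5 umol/kg. It also allows for the chance that compound 4, like compound 3, reaches only a limit. Compound 4 is expected to give about 200 umol/kg in this assay, between 50 umol/kg and 1000 umol/kg. For compound 4 this estimate means a 2.8-fold higher number from compound 2 to compound 4 (0.44 log units; beyond the scatter).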

Compound 4, dose for 50% inhibition: > 1000 umol/kg
Compound 4: a limit, no number; the forecaster's own chance of this, stated with the estimate: 50%; middle value at least 5.0-fold (0.69 log units) from the limit.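

In this assay, trifluoromethyl in place of methyl on an aromatic carbon, meta to a large group, gives an at least 13-fold higher number from compound 2 to compound 4 (1.13 log units; beyond the scatter). Compound 4 gives only a limit, the same one as compound 3: the limit of > 1000 umol/kg in this assay, at which 2 of the 4 values shown sit. The step from compound 1 to compound 3 cannot be read, so the two steps cannot be compared in size, and the data do not show whether the change has the same effect in both settings.

The compounds shown leave open how a methoxy group or a chlorine atom on the same aromatic carbon would fare in this assay. They also leave open whether a group of intermediate size, such as ethyl, would give a readable number there.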